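Compound 3: methoxy in place of fluoro

The source may report more compounds than this note shows. Statements on the series, on what has been measured and on what is new or still open speak of the compounds shown alone.

In a functional assay on OVCAR-3 cells (Homo sapiens) for inhibition, read by sulforhodamine B assay, with a stated time of 48 h (on this read-out higher numbers stand for weaker inhibition of growth and lower numbers for stronger inhibition of growth), compound 1 (`CCOC(=O)c1nn(-c2ccc(Cl)cc2)c(-c2ccc(F)cc2)c1CNC(C)(C)C`) gives 159000 nM; > 537000 nM (2 entries). Of these two entries of compound 1, the second is a limit of the assay, not a number. Among the measured compounds shown here, compound 2 (`CC(C)(C)NCc1c(C(=O)O)nn(-c2ccc(Cl)cc2)c1-c1ccc(F)cc1`) gives 116000 nM, its only number, with one further entry that carries no single number. That number lies within the usual scatter of the numbered entry of compound 1. Compound 3 (`COc1ccc(-c2c(CNC(C)(C)C)c(C(=O)O)nn2-c2ccc(Cl)cc2)cc1`) differs from compound 2 by methoxy in place of fluoro on an aromatic carbon, para to a large group: methoxy in place of fluoro on an aromatic carbon. For the measured compounds named here, no measured step sizes this change. The expected outcome in this assay is a 1.1-fold higher number from compound 2 to compound 3 (0.03 log units; within the scatter), within the usual scatter, with no direction favoured. Compound 3 is estimated at 125000 nM, with an expected range from 50000 nM to 300000 nM.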

Compound 3, concentration for 50% growth inhibition: 121000 nM
Compound 3: the middle estimate sits 1.0-fold (0.01 log units) above what was measured; the measured number falls inside the stated range.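

In this assay, among the compounds shown here, the first step that can be read at this position gives a 1.0-fold higher number from compound 2 to compound 3 (0.02 log units; within the scatter). The change from 4-fluorophenyl to 4-methoxyphenyl, on an aromatic carbon para to a large group, therefore leaves the read-out within the scatter, even though the entering methoxy carries 2 heavy atoms and 1 hydrogen-bond acceptor and the leaving fluoro carries 1 heavy atom and no acceptor. Nothing measured here bears on the cause of this result.

This single step cannot show whether any other group at this position would move the number beyond the scatter. On these data alone, what an amine or a longer chain, such as ethoxy, would do in this place remains open.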